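Series notes: chloro for amino on the shared core

The source may hold more compounds than are shown below. What is called first, only, known or untested is meant among the compounds shown, and "the series" means these compounds.

Compound 1 `ClCc1ccc(Cn2cnc3c(Cl)ncnc32)cc1` and compound 2 `Nc1nc(Cl)c2ncn(Cc3ccc(CCl)cc3)c2n1` share one core and differ only in the amino group. In a functional assay on CCRF-CEM cells (Homo sapiens) for cytotoxicity, read by sulforhodamine B assay, with a stated time of 48 h (on this read-out higher numbers stand for weaker inhibition of growth and lower numbers for stronger inhibition of growth), compound 1 gives 510 nM, while compound 2 gives 2690 nM; the change is a 5.3-fold higher number from compound 1 to compound 2 (0.72 log units; beyond the scatter). Within the data shown here, compound 2 therefore carries the highest of the two numbers so far, its only neighbour being compound 1.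

Compound 3 `ClCc1ccc(Cn2cnc3c(Cl)nc(Cl)nc32)cc1` differs from compound 2 by chloro in place of amino on an aromatic carbon. Among the measured compounds shown here, no measured pair sets chloro against amino at this carbon, so the only step that bears on the change is the one from compound 1 to compound 2, a modest rise when amino entered. Taking the amino away again, with chloro entering, is expected to pull the number back toward compound 1, so a lowering step is expected, a 3.4-fold lower number from compound 2 to compound 3 (0.53 log units; beyond the scatter). Compound 3 is estimated at 800 nM, with a range from 250 nM to 2500 nM.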

Compound 3, concentration for 50% growth inhibition: 1950 nM
Compound 3: the middle estimate sits 2.4-fold (0.39 log units) below what was measured; the range from low to high includes it.
By their numbers in this assay, from the lowest: compound 1; then compounds 3 and 2 (each within the scatter of the next).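

Replacing amino with chloro at this carbon, with a 1.4-fold lower number from compound 2 to compound 3 (0.14 log units; within the scatter) in this assay, gives no readable change, so the two groups cannot be told apart here. Chloro in place of hydrogen gives a 3.8-fold higher number from compound 1 to compound 3 (0.58 log units; beyond the scatter) on the same read-out, which shows that the rise seen with amino is not unique to that group: in these three compounds, both substituents stand apart from hydrogen, and neither stands apart from the other. No measured evidence accounts for this behaviour at the position.

The compounds shown leave open whether fluoro, methyl or methoxy at this carbon would follow chloro and amino, or would stay with hydrogen. They also leave open whether any group here can give a number lower than that of compound 1, at 510 nM on this read-out.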